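Trimming the hydroxylated chain of compound 3

The source may report more compounds than this note shows. Statements on the series, on what has been measured and on what is new or still open speak of the compounds shown alone.

Three compounds share one core. Compound 1 `COc1cc(N(CC(C)C)c2ccc(F)c3ccccc23)cnc1C(=O)[C@H]1C[C@@H]1C(=O)O` gives 0.381 nM in an assay for inhibition of leukotriene C4 synthase (Homo sapiens), read by LC-MS, with stated times of 15 min and 30 min (on this read-out higher numbers stand for weaker inhibition and lower numbers for stronger inhibition), and compound 2 `CCCN(c1cnc(C(=O)[C@H]2C[C@@H]2C(=O)O)c(OC)c1)c1ccc(F)c2ccccc12` gives 0.626 nM in this assay; the step of a 1.6-fold higher number from compound 1 to compound 2 (0.22 log units; within the scatter) lies within the scatter. Compound 3 `COc1cc(N(CC(C)(C)O)c2cccc(C(F)(F)F)c2)cnc1C(=O)[C@H]1C[C@@H]1C(=O)O` gives 31.8 nM in this assay, the highest of the three numbers and beyond the scatter from both others, so it is the weakest inhibitor of the set. Compound 4 `CCN(c1cccc(C(F)(F)F)c1)c1cnc(C(=O)[C@H]2C[C@@H]2C(=O)O)c(OC)c1` differs from compound 3 by methyl in place of 1-hydroxy-1-methylethyl on a saturated chain carbon bound to a nitrogen on an aromatic ring. Among the compounds with values here, only the step of a 1.6-fold higher number from compound 1 to compound 2 (0.22 log units; within the scatter) bears loosely on this, since it also shortens the chain on the nitrogen, and it stayed within the scatter; the loss of the hydroxyl has no measured counterpart. A modest lowering of the number is therefore expected, a 2.1-fold lower number from compound 3 to compound 4 (0.33 log units; beyond the scatter), possibly within the scatter. Compound 4 is estimated at 15 nM, between 4 nM and 60 nM.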

Compound 4, half-maximal inhibitory concentration: 13 nM
For compound 4 the middle estimate is 1.2-fold (0.06 log units) above the measured one; the range from low to high includes it.
By their numbers in this assay, from the lowest: compounds 1 and 2 (each within the scatter of the next); then compound 4; then compound 3.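

Methyl in place of 1-hydroxy-1-methylethyl on a saturated chain carbon bound to a nitrogen on an aromatic ring gives a 2.4-fold lower number from compound 3 to compound 4 (0.39 log units; beyond the scatter) in this assay, a modest step but beyond the scatter. This position therefore accepts ethyl, and inhibition here does not depend on keeping the 2-hydroxy-2-methylpropyl chain. Nothing available explains the step.

The change removes the hydroxyl and the branching carbons together, so their separate contributions remain unresolved. A chain ending in an amine or a methyl ether at this position would test whether the hydroxyl itself matters.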